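The compounds below may be only part of what the source reports. "The series", "measured", "known", "first", "only" and "open" are said of these compounds alone.

Compound 1 `CCN(CC)c1ccc(C(F)(F)F)cc1NC(=O)c1cccnc1` gives 63200 nM in a functional assay on NALM-6 cells (Homo sapiens) for cytotoxicity, read by MTT assay, with a stated time of 48 h; a higher number here means a weaker inhibitor, a lower number a stronger inhibitor.
Compound 2 `O=C(Nc1cc(C(F)(F)F)ccc1NC1CCCCC1)c1cccnc1` gives 52300 nM in this assay.

For the measured compounds named here, compound 1 holds the highest of these two numbers, with compound 2 nearest; the only measured step, a 1.2-fold lower number from compound 1 to compound 2 (0.08 log units; within the scatter), is within the scatter and concerns the amine on the aromatic carbon, not the carbonyl side. Compound 3 `CCN(CC)c1ccc(C(F)(F)F)cc1NC(=O)c1ccncc1` differs from compound 1 in this way: pyridin-4-yl in place of pyridin-3-yl on a carbonyl carbon. Going by the values given here, no measured step touches that part of the molecule, so nothing in the data argues for a change beyond the scatter. Compound 3 is therefore expected near compound 1, at 60000 nM (range 20000 nM to 150000 nM), an expected step of a 1.1-fold lower number from compound 1 to compound 3 (0.02 log units; within the scatter).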

Compound 3, half-maximal inhibitory concentration: 63600 nM
For compound 3 the middle estimate is 1.1-fold (0.03 log units) below the measured one; low and high end bracket the measured number.
By their numbers in this assay, from the lowest: compounds 2, 1 and 3 (each within the scatter of the next).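

The carbonyl side of the molecule now has a measured step of its own: with pyridin-4-yl in place of pyridin-3-yl on a carbonyl carbon, this assay shows a 1.0-fold higher number from compound 1 to compound 3 (0.00 log units; within the scatter). Between these two pyridine rings, then, the choice of attachment leaves the two numbers within the scatter of each other. No available evidence bears on the reason for this.

The compounds shown leave open whether a phenyl ring at this carbonyl carbon, or a nitrile in place of the trifluoromethyl group on the shared core, would give a step beyond the scatter.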